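The source may report more compounds than this note shows. Statements on the series, on what has been measured and on what is new or still open speak of the compounds shown alone.

Measured compounds:
Compound 1: `COc1cc(OC)c(C(=O)/C=C/c2cccc(N3CCNCC3)c2)c(O)c1C`; in an ADME assay on MCF7-DOX cells (Homo sapiens) for cytotoxicity, read by MTT assay, with a stated time of 48 h (on this read-out higher numbers stand for weaker inhibition and lower numbers for stronger inhibition), compound 1 gives 98700 nM.
Compound 2: `CCc1c(OC)cc(OC)c(C(=O)/C=C/c2cccc(N3CCNCC3)c2)c1O`; in this assay compound 2 gives only a limit of the assay, > 100000 nM.

Compound 2 therefore does not stand at a number at all. Its result is a limit of the assay, not a measured concentration, a point also made by the limit of > 100000 nM in this assay, at which 1 of the 2 values shown sits. For the measured compounds named here, compound 1 is the only member of the pair with an actual number, and both compounds sit at the weak end of what this assay can report.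

The unmeasured compound 3 is `CCCCc1c(OC)cc(OC)c(C(=O)/C=C/c2cccc(N3CCNCC3)c2)c1O`. It differs from compound 2 in one place: ethyl in place of hydrogen on a saturated chain carbon, two bonds along the chain from an aromatic carbon. Going by the values given here, the only measured step that bears on this kind of change is an at least 1.0-fold higher number from compound 1 to compound 2 (0.00 log units; that floor lies within the scatter), which adds a small saturated group at the same part of the shared core and produces no movement beyond the scatter. Extending that chain further by two carbons gives no reason, from the data shown, to expect a step of any size in this assay; the most likely outcome is another limit.

Compound 3 is therefore expected to give about 140000 nM, within 50000 nM to 400000 nM, meaning an expected step that the limit leaves unreadable from compound 2 to compound 3.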

Compound 3, half-maximal inhibitory concentration: > 100000 nM
Compound 3 was reported as a limit; the forecaster's own chance of this, stated with the estimate: 75%; the middle value does not contradict the limit.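

Compound 3 stops at a limit of the assay, not at a measured concentration, and so joins compound 2 at the weak end of this assay: the limit of > 100000 nM in this assay, at which 2 of the 3 values shown sit.

With a limit on both sides, the step between compound 2 and compound 3 cannot be read. For the compounds shown here, the one comparison that can be read is an at least 1.0-fold higher number from compound 1 to compound 3 (0.00 log units; that floor lies within the scatter). What this adds is that a chain grown as far as butyl at this place, and not only the ethyl of compound 2, still gives no sign of stronger inhibition in this read-out.

As far as these compounds go, how far compound 2 and compound 3 lie past the limit stays unknown, so the data cannot say whether chain length matters at all at this place. Also open, from the compounds shown here alone, is whether an amine or a carboxylic acid at the end of this chain, or a small group such as hydroxyl on the chain carbon, would bring a compound back to a number that can be compared with compound 1.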